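The source may hold more compounds than are shown below. What is called first, only, known or untested is meant among the compounds shown, and "the series" means these compounds.

In a functional assay on HeLa cells (Homo sapiens) for inhibition, with a stated time of 72 h (on this read-out lower numbers stand for an effect already at smaller amounts and higher numbers for an effect only at larger amounts of compound), compound 1 `COc1cc(CNC2CCCCC2)ccc1OCc1ccc(Cl)nc1` offers no number to start from, and its entry reads "nd(insoluble)" (no result reported). Two related compounds do have numbers. Compound 3 `COc1cc(OCc2ccc(Cl)cc2)ccc1CNCc1ccncc1` gives 440 nM, and compound 2 `COc1cc(CNCc2ccncc2)ccc1OCc1ccc(C)cc1` gives 5000 nM, so compound 3 acts at clearly smaller amounts than compound 2. Both differ from compound 1 in more than one place, which makes them only a loose guide.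

The next compound to be tested is compound 4 `COc1cc(CNCCCN(C)C)ccc1OCc1ccc(Cl)nc1`. It keeps the core of compound 1 and changes one group: 3-(dimethylamino)propyl takes the place of cyclohexyl on an amine nitrogen (3-(dimethylamino)propyl in place of cyclohexyl on an amine nitrogen). The two groups have the same number of heavy atoms, but the incoming group is an open chain and carries a nitrogen, whereas the outgoing group is a ring of carbon only.

With no reading for compound 1, neither the size nor the direction of this step can be stated in this assay. The expectation is simply that compound 4 gives a number in the same broad region as the two measured compounds, resting on compound 3 at 440 nM and compound 2 at 5000 nM. The estimate for compound 4 is 2000 nM, with an expected range from 300 nM to 12000 nM.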

Compound 4, half-maximal effective concentration: 5000 nM
Beside the measured number, compound 4's estimate is 2.5-fold (0.40 log units) below it; the measured number falls inside the stated range.
By their numbers in this assay, from the lowest: compound 3; then compounds 2 and 4 (each within the scatter of the next).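

Compound 1 has no number to set against compound 4, so the change from cyclohexyl to 3-(dimethylamino)propyl cannot be read as a step. The compounds shown leave open whether this change moves the read-out at all, and in which direction. Nothing shown offers an explanation for the result of compound 4.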